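The compounds below may be only part of what the source reports. "The series", "measured", "known", "first", "only" and "open" are said of these compounds alone.

Measured so far in a functional assay on SGC-7901 cells (Homo sapiens) for antiproliferative activity, read by MTT assay, with a stated time of 24 h; on this read-out lower numbers stand for stronger inhibition and higher numbers for weaker inhibition:

Compound 1, `Cc1cccc(-n2cc(-c3ccccc3NS(=O)(=O)c3c[nH]c(=O)[nH]c3=O)nn2)c1`: 3510 nM
Compound 2, `Cc1ccc(-n2cc(-c3ccccc3NS(=O)(=O)c3c[nH]c(=O)[nH]c3=O)nn2)cc1`: 6390 nM
Compound 3, `Cc1cccc(-n2cc(-c3cccc(NS(=O)(=O)c4c[nH]c(=O)[nH]c4=O)c3)nn2)c1`: 9100 nM

Compound 1 and compound 2 share one core and differ in a single place: 4-methylphenyl in place of 3-methylphenyl on an aromatic nitrogen. This change made the step of a 1.8-fold higher number from compound 1 to compound 2 (0.26 log units; within the scatter), so the two numbers cannot be told apart with confidence. Compound 3 carries the other core; how its core differs from that of compound 1 is not broken down here. Compound 3 gives the highest of the three numbers, but its value and that of compound 2 lie within the scatter of each other, while its step from compound 1 is beyond it.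

Compound 4, `Cc1ccc(-n2cc(-c3cccc(NS(=O)(=O)c4c[nH]c(=O)[nH]c4=O)c3)nn2)cc1`, has not yet been tested in this assay. It differs from compound 3 by 4-methylphenyl in place of 3-methylphenyl on an aromatic nitrogen, the same change that was made from compound 1 to compound 2. Because a 1.8-fold higher number from compound 1 to compound 2 (0.26 log units; within the scatter) was small, a step of about the same size is expected from compound 3 to compound 4, a 1.4-fold higher number from compound 3 to compound 4 (0.15 log units; within the scatter). Compound 4 is therefore estimated at 13000 nM, with a range from 6000 nM to 30000 nM.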

Compound 4, half-maximal inhibitory concentration: 9430 nM
Compound 4: middle estimate off by 1.4-fold (0.14 log units), on the high side, within the range that was stated.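

In this assay, putting 4-methylphenyl in place of 3-methylphenyl on the aromatic nitrogen gives a 1.0-fold higher number from compound 3 to compound 4 (0.02 log units; within the scatter), so on this core, too, the two groups cannot be told apart. Set side by side, the two steps do not differ by more than repeated measurements could explain, which means the change reads the same on both cores as far as these numbers can tell: the same change on two cores in this assay, a 1.8-fold higher number (0.26 log units; within the scatter) from compound 1 to compound 2 and a 1.0-fold higher number (0.02 log units; within the scatter) from compound 3 to compound 4, 1.8-fold (0.24 log units) apart, within the scatter of two such steps. Within the data shown here, this shows only that the change stayed within the scatter on two cores; it does not fix an exact size for the step, and two pairs cannot show that it would stay as small on a further core.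

All the compounds shown carry a methyl group on the outer phenyl ring, which leaves open what a methoxy group, a chlorine atom or a carboxylic acid would do there. Also open, as far as these compounds go, is how a plain phenyl ring or an ethyl group in place of the methyl would compare on either core.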